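A few compounds are considered here, and "the series" means these few. Any claim that something is new, unique, unknown or untested is made for them only; others in the source may bear on it.

Compound 1 `C[C@@H]1N[C@H](C(=O)N2CCC[C@H]2C#N)C[C@@H]1C(=O)N1CCCC1`: 94%
Compound 2 `C[C@@H]1N[C@H](C(=O)N2CCC[C@H]2C#N)C[C@@H]1C(=O)N1CCSCC1`: 92%
Compound 3 `C[C@@H]1N[C@H](C(=O)N2CCC[C@H]2C#N)C[C@@H]1C(=O)N1CCCCC1`: 91%

In an assay on the whole organism (plasma, strain Sprague-Dawley) for inhibition of Dipeptidyl peptidase 4 (Rattus norvegicus), with a stated time of 6 h, at a dose of 1 mg/kg by the oral route (a lower number here means less inhibition, a higher number more inhibition at the dose given (going by the name of the read-out)), compound 3 gives 91%, the smallest of the three numbers, yet a number 3 percentage points lower from compound 1 to compound 3 (within the scatter) and a number 1 percentage points lower from compound 2 to compound 3 (within the scatter), so the three compounds are not told apart. Compound 4 `C[C@@H]1N[C@H](C(=O)N2CCC[C@H]2C#N)C[C@@H]1C(=O)N(C)C` differs from compound 3 in one place: dimethylamino in place of piperidin-1-yl on a carbonyl carbon. Every measured step swaps the ring amine on that carbonyl carbon for another ring amine: a number 2 percentage points lower from compound 1 to compound 2 (within the scatter), a number 3 percentage points lower from compound 1 to compound 3 (within the scatter), a number 1 percentage points lower from compound 2 to compound 3 (within the scatter). Within the data shown here, none of them replaces the ring with an open chain, so the step to compound 4 has no exact precedent, but three swaps at the same place left the inhibition unchanged. Compound 4 is therefore expected to give about 88%, between 72% and 97%, meaning a number 3 percentage points lower from compound 3 to compound 4 (within the scatter), a step expected to stay within the scatter.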

Compound 4, a percentage reported as inhibition, in the whole organism at one dose (the size of the read-out at that dose, not a potency): 95%
Compound 4: the middle estimate sits 7 percentage points below what was measured, within the range that was stated.
By their numbers in this assay, from the lowest: compounds 3, 2, 1 and 4 (each within the scatter of the next).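

In this assay dimethylamino, an open chain, cannot be told apart from any of the three ring amines on this carbonyl carbon (a number 4 percentage points higher from compound 3 to compound 4 (within the scatter) and a number 3 percentage points higher from compound 2 to compound 4 (within the scatter) and a number 1 percentage points higher from compound 1 to compound 4 (within the scatter)). So a ring at this place is not needed to hold the read-out at this dose, and 3 heavy atoms serve as well as the 6 of piperidin-1-yl. Nothing available explains this result.

From the compounds shown here alone, a longer chain such as diethylamino, or a carboxylic acid at this place, remains open. So does whether these similar single-dose numbers hide differences in potency.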